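A few compounds are considered here, and "the series" means these few. Any claim that something is new, unique, unknown or untested is made for them only; others in the source may bear on it.

Measured compounds:
Compound 1 `COC(=O)C(O)Cn1cnc2c(N)ncnc21`: in a functional assay on HeLa cells (Homo sapiens) for cytotoxicity (a higher number here means that more compound is tolerated, a lower number that less compound is tolerated), compound 1 gives > 400 ug/mL, which is a limit of the assay.
Compound 2 `CCCOC(=O)C(O)Cn1cnc2c(N)ncnc21`: compound 2 gives > 400 ug/mL, again a limit.
Compound 3 `CCC(C)OC(=O)C(O)Cn1cnc2c(N)ncnc21`: compound 3 gives > 400 ug/mL, also a limit.

From compound 2 to compound 1 the change is hydrogen in place of ethyl on a saturated chain carbon bound to an oxygen next to a carbonyl group; the step it made is a step that the two limits leave unreadable from compound 2 to compound 1. Compound 4 `CCOC(=O)C(O)Cn1cnc2c(N)ncnc21` is not yet measured; from compound 3 to compound 4 the change is hydrogen in place of ethyl on a saturated chain carbon bound to an oxygen next to a carbonyl group and a saturated chain carbon. This is the same kind of change, not the same: here the place is on a saturated chain carbon bound to an oxygen next to a carbonyl group and a saturated chain carbon. The two cores differ by methyl in place of hydrogen on a saturated chain carbon bound to an oxygen next to a carbonyl group and a saturated chain carbon, with the step that the two limits leave unreadable from compound 2 to compound 3; from compound 1 to compound 3 the step is a step that the two limits leave unreadable from compound 1 to compound 3. Because (the limit of > 400 ug/mL in this assay, at which 3 of the 3 values shown sit), the step from compound 3 to compound 4 is expected to be a number no higher from compound 3 to compound 4 (the limit leaves the size open). Compound 4 is estimated at 400 ug/mL, most likely again a limit.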

Compound 4, minimum cytotoxic concentration: > 400 ug/mL
Compound 4: only a limit was reported (the forecaster's own chance of this, stated with the estimate: 90%); the middle value lies on the limit itself.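

No step from compound 4 to compound 1, compound 2 or compound 3 can be read in this assay: the limit of > 400 ug/mL in this assay, at which 4 of the 4 values shown sit.

The compounds shown leave open how far each tolerated concentration lies past that limit, and whether the changes among these four compounds alter it at all.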